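This account rests on a few compounds, and the source may have more. Where it says the series, first, only, none or still open, it means among the compounds named here.

Measured in a functional assay on HeLa cells (Homo sapiens) for inhibition, read by CCK-8 assay, with a stated time of 48 h; a lower number here means a stronger inhibitor, a higher number a weaker inhibitor:
- Compound 1 `COc1cc(-c2ccnc3cc(-c4ccc(F)cc4)nn23)cc(OC)c1OC`: 5840 nM
- Compound 2 `COc1cc(-c2ccnc3cc(-c4cccc(C#N)c4)nn23)cc(OC)c1OC`: > 10000 nM (a limit of the assay, not a number)
- Compound 3 `COc1cc(-c2ccnc3cc(-c4ccc5c(ccn5C)c4)nn23)cc(OC)c1OC`: 19 nM

Going by the values given here, compound 3 has the lowest number of the set, far below compound 1, the only other exact value. Compound 4 `COc1cc(-c2ccnc3cc(-c4ccc(N(C)C)cc4)nn23)cc(OC)c1OC` keeps the shared core and changes one group: 4-(dimethylamino)phenyl in place of 1-methyl-1H-indol-5-yl on an aromatic carbon. Among the compounds with values here, two measured steps bear on this, both swaps on the same aromatic carbon: a 310-fold lower number from compound 1 to compound 3 (2.49 log units; beyond the scatter) and an at least 520-fold lower number from compound 2 to compound 3 (2.72 log units; beyond the scatter). Both are large, and both end at the 1-methyl-1H-indol-5-yl group that compound 4 gives up. Like compound 1, with 5840 nM, compound 4 carries a substituted phenyl, so a clearly higher number is expected in this assay, though the different substituent may keep the rise smaller. The expected change is a 16-fold higher number from compound 3 to compound 4 (1.20 log units; beyond the scatter). The estimate for compound 4 is 300 nM, with an expected range from 40 nM to 3000 nM.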

Compound 4, half-maximal inhibitory concentration: 378 nM
Beside the measured number, compound 4's estimate is 1.3-fold (0.10 log units) below it; measured number inside the range.
By their numbers in this assay, from the lowest: compound 3; then compound 4; then compound 1. At a limit, above all of these: compound 2.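

In this assay, a phenyl at this position need not give a high number: with only dimethylamino in place of fluoro, there is a 15-fold lower number from compound 1 to compound 4 (1.19 log units; beyond the scatter). Even so, this phenyl does not replace the 1-methyl-1H-indol-5-yl group without loss, with a 20-fold higher number from compound 3 to compound 4 (1.30 log units; beyond the scatter). The third step starts from a limit, not a number, so an at least 26-fold lower number from compound 2 to compound 4 (1.42 log units; beyond the scatter) is only a floor: the limit of > 10000 nM in this assay, at which 1 of the 4 values shown sits.

Still open, from the compounds shown here alone, is whether an amino or morpholine group on the phenyl would behave like dimethylamino. Also open, going by these compounds, is whether an indole lacking the methyl group would keep the low number of compound 3.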